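Imine aryl exchange on the shared core

The source may hold more compounds than are shown below. What is called first, only, known or untested is meant among the compounds shown, and "the series" means these compounds.

Two members of the series are measured. Compound 1 `CN(C)CCn1cnnc1-c1cc(Oc2ccc(NC(=O)N/N=C/c3c[nH]c4ccccc34)cc2F)ccn1` gives 790 nM in a functional assay on MKN-45 cells (Homo sapiens) for cytotoxicity, read by MTT assay, with a stated time of 72 h; a lower number here means a stronger inhibitor, a higher number a weaker inhibitor. Compound 2 `CN(C)CCn1cnnc1-c1cc(Oc2ccc(NC(=O)N/N=C/c3ccc(O)c(O)c3)cc2F)ccn1` gives 3240 nM in this assay, the highest of the two numbers; the nearest is compound 1, and the step is a 4.1-fold higher number from compound 1 to compound 2 (0.61 log units; beyond the scatter). Compound 3 `CN(C)CCn1cnnc1-c1cc(Oc2ccc(NC(=O)N/N=C/c3cccc(Cl)c3Cl)cc2F)ccn1` is not yet measured; it differs from compound 2 by 2,3-dichlorophenyl in place of 3,4-dihydroxyphenyl on a carbon with a double bond to nitrogen. Among the measured compounds shown here, no measured step matches this exchange directly. For the measured compounds named here, the only step that bears on it is the one exchanging the aryl group on the same carbon, a 4.1-fold higher number from compound 1 to compound 2 (0.61 log units; beyond the scatter), which was modest. Going by the values given here, a step of similar size in this assay is therefore expected, more likely downward than upward, because compound 2 stands at 3240 nM, the highest number so far. For compound 3 the expected step is a 2.2-fold lower number from compound 2 to compound 3 (0.33 log units; beyond the scatter). Compound 3 is estimated at 1500 nM, within 500 nM to 5000 nM.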

Compound 3, half-maximal inhibitory concentration: 51 nM
The estimate for compound 3 lay 29-fold (1.47 log units) above the measured number, outside the stated range (below it).
By their numbers in this assay, from the lowest: compound 3; then compound 1; then compound 2.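

In this assay the aryl group on the carbon with a double bond to nitrogen controls a much wider range than the first exchange suggested: 2,3-dichlorophenyl gives a 64-fold lower number from compound 2 to compound 3 (1.80 log units; beyond the scatter) and also a 15-fold lower number from compound 1 to compound 3 (1.19 log units; beyond the scatter). Both steps are large, whereas the earlier aryl exchange was modest. Heavy-atom count and the six-membered aromatic ring stay unchanged from 3,4-dihydroxyphenyl to 2,3-dichlorophenyl, while hydrogen-bond donors and acceptors leave and chlorine enters, and no measurement here separates these changes or explains the step.

From the compounds shown here alone, it remains open whether the chlorines are needed at all, which a plain phenyl would test against compound 3. A bromophenyl or an aminophenyl on the same carbon would show how far this gain extends across other aryl groups.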